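The source may hold more compounds than are shown below. What is called first, only, known or untested is meant among the compounds shown, and "the series" means these compounds.

Measured compounds:
- compound 1, `COc1ccc(-c2cc(Cl)cc(Cl)c2/C=C/[C@@H]2C[C@@H](O)CC(=O)O2)cc1`: 470 nM
- compound 2, `Cc1cc(F)ccc1-c1cc(Cl)cc(Cl)c1/C=C/[C@@H]1C[C@@H](O)CC(=O)O1`: 36 nM
- compound 3, `Cc1cc(C)cc(-c2cc(Cl)cc(Cl)c2/C=C/[C@@H]2C[C@@H](O)CC(=O)O2)c1`: 13 nM

In an assay for inhibition of 3-hydroxy-3-methylglutaryl-coenzyme A reductase (Rattus norvegicus) (a higher number here means a weaker inhibitor, a lower number a stronger inhibitor), compound 3 gives the lowest number of the three. Its nearest neighbour is compound 2, from which the step of a 2.8-fold lower number from compound 2 to compound 3 (0.44 log units; beyond the scatter) is modest; compound 1 lies furthest off, the step of a 36-fold lower number from compound 1 to compound 3 (1.56 log units; beyond the scatter) being large. The other measured step, a 13-fold lower number from compound 1 to compound 2 (1.12 log units; beyond the scatter), is also large, so the two changes away from the 4-methoxyphenyl group of compound 1 both lower the number considerably.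

Compound 4, `COc1cccc(-c2cc(Cl)cc(Cl)c2/C=C/[C@@H]2C[C@@H](O)CC(=O)O2)c1`, carries 3-methoxyphenyl in place of 3,5-dimethylphenyl on an aromatic carbon. Going by the values given here, no measured step covers exactly this exchange. What bears on it is the pair of compound 1 and compound 3: one methoxy-bearing phenyl gave the highest number of the series, the dimethyl-bearing phenyl the lowest. Compound 4 keeps a methoxy group but moves it to the place where compound 3 carries its methyl groups, so the number is expected to rise again, probably landing between compound 3 and compound 1 rather than reaching compound 1.

For compound 4 the estimate in this assay is 80 nM, within 25 nM to 300 nM, which is an expected step of a 6.2-fold higher number from compound 3 to compound 4 (0.79 log units; beyond the scatter).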

Compound 4, half-maximal inhibitory concentration: 50 nM
Estimate against measurement, compound 4: 1.6-fold (0.20 log units) above; the range from low to high includes it.
By their numbers in this assay, from the lowest: compound 3; then compounds 2 and 4 (each within the scatter of the next); then compound 1.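

In this assay, exchanging 4-methoxyphenyl for 3-methoxyphenyl gives a 9.4-fold lower number from compound 1 to compound 4 (0.97 log units; beyond the scatter) so on this aromatic carbon the outcome depends on where the methoxy group sits on the phenyl ring, not only on whether one is present. Compound 3 still keeps an edge, with 3-methoxyphenyl in place of 3,5-dimethylphenyl giving a 3.8-fold higher number from compound 3 to compound 4 (0.59 log units; beyond the scatter) and so a methoxy-bearing phenyl comes closer to the dimethyl-bearing one than compound 1 suggested. The 3-methoxyphenyl and 4-fluoro-2-methylphenyl groups cannot be separated here, with a 1.4-fold higher number from compound 2 to compound 4 (0.14 log units; within the scatter) as the step between them.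

Nothing among the data shown accounts for these differences. Also open, going by these compounds, is how 3-methylphenyl, 3-ethoxyphenyl or a phenyl ring carrying an amine or a carboxylic acid would compare on this same aromatic carbon.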